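Sulfur substituent variation on a shared core

The source may hold more compounds than are shown below. What is called first, only, known or untested is meant among the compounds shown, and "the series" means these compounds.

Measured so far in a functional assay on HeLa cells (Homo sapiens) for cytotoxicity; on this read-out higher numbers stand for weaker inhibition and lower numbers for stronger inhibition:
compound 1 `CC1=CCC[C@H]2[C@](C)(CC3=CC(=O)C=C(Sc4ccccc4)C3=O)[C@@H](C)CC[C@]12C` gives 54800 nM.
compound 2 `CCCSC1=CC(=O)C(C[C@]2(C)[C@@H](C)CC[C@]3(C)C(C)=CCC[C@@H]23)=CC1=O` gives 97000 nM.
compound 3 `CC1=CCC[C@H]2[C@](C)(CC3=CC(=O)C4=C(SCCS4)C3=O)[C@@H](C)CC[C@]12C` reports only a limit, > 100000 nM.

Among the two plain numbers in this assay compound 2 holds the higher one; the gap to compound 1 stays within the scatter, so the two read as alike. The value for compound 3 is a limit, sitting at the limit of > 100000 nM in this assay, at which 1 of the 3 values shown sits. Compound 4 `CC1=CCC[C@H]2[C@](C)(CC3=CC(=O)C(SC(C)(C)C)=CC3=O)[C@@H](C)CC[C@]12C` alters the sulfur substituent of compound 2: tert-butyl in place of propyl on a sulfur. Within the data shown here, no measured pair differs in one place only, so no step size is known from the series itself. For the propyl to tert-butyl exchange the expected step from compound 2 to compound 4 is a 1.1-fold lower number from compound 2 to compound 4 (0.03 log units; within the scatter), nothing beyond the scatter. Compound 4 is therefore estimated at 90000 nM, within 45000 nM to 180000 nM, with a fair chance that only a limit is reported.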

Compound 4, half-maximal inhibitory concentration: 37000 nM
Estimate against measurement, compound 4: 2.4-fold (0.39 log units) above; measured number below the stated range.
By their numbers in this assay, from the lowest: compounds 4, 1 and 2 (each within the scatter of the next, the first and the last beyond it). At a limit, above all of these: compound 3.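

In this assay, tert-butyl in place of propyl on a sulfur gives the first step readable in the series: a 2.6-fold lower number from compound 2 to compound 4 (0.42 log units; beyond the scatter). A one-place change at this sulfur therefore moves the number beyond the scatter, though the step is modest and rests on a single pair. Nothing measured here gives a reason for this step. Still open, going by these compounds, is whether isopropyl, a longer chain such as hexyl, or an aminoethyl group on this sulfur would shift the number further, and in which direction.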